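This account rests on a few compounds, and the source may have more. Where it says the series, first, only, none or still open, it means among the compounds named here.

In a functional assay on HCT-116 cells (Homo sapiens) for cytotoxicity, read by MTT assay, with a stated time of 48 h (on this read-out lower numbers stand for stronger inhibition of growth and higher numbers for weaker inhibition of growth), compound 1 `O=C1Nc2ccccc2/C1=N/NC(=S)N1CCN(C(=O)NO)CC1` reads > 100000 nM, which is a limit of the assay and not a number. Among the measured compounds shown here, compound 2 `O=C(NO)N1CCN(C(=S)N/N=C/c2ccccc2O)CC1` gives 8600 nM, the only true number available so far, so it is the sole numerical reference point. Compound 3 `O=C(NO)N1CCN(C(=S)N/N=C/c2ccccc2Cl)CC1` differs from compound 2 in one place, with chloro in place of hydroxy on an aromatic carbon, ortho to a large group: chloro in place of hydroxy on an aromatic carbon. For the measured compounds named here, no measured pair shows what this exchange does, so any forecast here is tentative. In this assay, a moderate step towards weaker inhibition of growth is expected, though a result within the usual scatter would not surprise. The expected step of a 2.1-fold higher number from compound 2 to compound 3 (0.32 log units; beyond the scatter) is an estimate with wide uncertainty. For compound 3 the estimated value is 18000 nM, with an expected range from 4500 nM to 75000 nM.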

Compound 3, concentration for 50% growth inhibition: 11500 nM
Beside the measured number, compound 3's estimate is 1.6-fold (0.19 log units) above it, and the stated range covers the measured number.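

In this assay, chloro in place of hydroxy on an aromatic carbon, ortho to a large group, gives a 1.3-fold higher number from compound 2 to compound 3 (0.13 log units; within the scatter), so the two compounds cannot be told apart on this read-out. The hydrogen-bond donor and acceptor counted for hydroxy are both gone in chloro, and in this one pair their loss brings no step beyond the scatter, so activity at this place does not rest on the hydroxy group alone. Nothing shown here bears on the cause of this step.

Going by these compounds, whether an amine, a carboxylic acid or a methoxy group at this place would read the same remains open, as does the same exchange on other carbons of the ring. Among the compounds shown here, compound 1 reads > 100000 nM, a limit and not a number, so no step to it can be read.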